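Methoxy in Place of Hydrogen: Estimating Compound 3

This account rests on a few compounds, and the source may have more. Where it says the series, first, only, none or still open, it means among the compounds named here.

Measured so far:
- Compound 1, `CCN(CC)C(=S)SC(CC(=O)c1ccccc1)c1ccccc1`, 17000 nM
- Compound 2, `CCN(CC)C(=S)SC(CC(=O)c1ccccc1)c1ccc(F)cc1`, 700 nM

Both numbers come from a functional assay on MCF7 cells (Homo sapiens) for cytotoxicity, read by MTT assay, with a stated time of 48 h; on this read-out higher numbers stand for weaker inhibition and lower numbers for stronger inhibition. Compound 1 stands highest of the two measured compounds, meaning it is the weaker inhibitor; its nearest neighbour is compound 2, and the step of a 24-fold lower number from compound 1 to compound 2 (1.39 log units; beyond the scatter) is large and lies well beyond the usual scatter. Among the measured compounds shown here, the only measured change, then, is fluoro in place of hydrogen on an aromatic carbon, and it lowered the number sharply.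

Compound 3, `CCN(CC)C(=S)SC(CC(=O)c1ccc(OC)cc1)c1ccccc1`, has not yet been measured in this assay. It differs from compound 1 in one place: methoxy in place of hydrogen on an aromatic carbon. Put another way, the change reads phenyl to 4-methoxyphenyl. For the measured compounds named here, no measured step involves a methoxy group, so the step from compound 1 to compound 2 bears on compound 3 only loosely, as a sign that a single small substituent on an aromatic carbon can shift the number a great deal. A modest move toward stronger inhibition is expected, but with wide uncertainty.

Compound 3 is therefore estimated at 8000 nM, with a likely range from 2000 nM to 35000 nM, an expected step of a 2.1-fold lower number from compound 1 to compound 3 (0.33 log units; beyond the scatter).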

Compound 3, half-maximal inhibitory concentration: 4500 nM
Beside the measured number, compound 3's estimate is 1.8-fold (0.25 log units) above it; measured number inside the range.
By their numbers in this assay, from the lowest: compound 2; then compound 3; then compound 1.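

In this assay the change from phenyl to 4-methoxyphenyl gives a 3.8-fold lower number from compound 1 to compound 3 (0.58 log units; beyond the scatter), a modest step, but one that lies beyond the usual scatter. It shows that a methoxy group on an aromatic carbon, para to a large group, also moves the number toward stronger inhibition, so the fluoro group of compound 2 is no longer the only substituent seen to do so on this shared core. Nothing available explains why the number moves, and no supporting data bear on the cause of this step.

Compound 2 and compound 3 differ from each other in more than one place, so their steps from compound 1 cannot rank fluoro against methoxy at a single position. As far as these compounds go, it also remains open whether the step depends on the oxygen of the methoxy group or on the group as a whole, a question that a hydroxyl group, a longer ethoxy chain or an amine at this same place would help to settle.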